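Biphenyl to tert-butyl: a single change on the shared core

The source may report more compounds than this note shows. Statements on the series, on what has been measured and on what is new or still open speak of the compounds shown alone.

Measured so far:
- compound 1, `O=S(=O)(NCCNCc1cccc2ccccc12)c1cc(C(F)(F)F)cc(C(F)(F)F)c1`: 21000 nM
- compound 2, `O=S(=O)(NCCNCc1ccc(-c2ccccc2)cc1)c1cc(C(F)(F)F)cc(C(F)(F)F)c1`: 2600 nM

Two compounds share the bis(trifluoromethyl)benzenesulfonamide core and differ only in the aromatic group carried on the far end of the linker. In a functional assay on A2780 cells (Homo sapiens) for inhibition, read by MTT assay, with a stated time of 72 h (on this read-out lower numbers stand for stronger inhibition of growth and higher numbers for weaker inhibition of growth), compound 1 gives 21000 nM. In this assay compound 2 gives 2600 nM, the lowest of the two numbers, and its nearest neighbour, compound 1, sits at a higher number well beyond the scatter. Within the data shown here, no step between measured compounds that differ in one place is available, so the size of any single change has not yet been seen.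

Compound 3, `CC(C)(C)c1ccc(CNCCNS(=O)(=O)c2cc(C(F)(F)F)cc(C(F)(F)F)c2)cc1`, is the next to be measured. It differs from compound 2 by tert-butyl in place of phenyl on an aromatic carbon. Among the measured compounds shown here, there is no measured precedent for this exchange on this core, so the direction of the step is uncertain. On the numbers alone compound 3 is expected to stay close to compound 2, with the step from compound 2 to compound 3 estimated as a 1.3-fold higher number from compound 2 to compound 3 (0.13 log units; within the scatter), allowing for a modest loss. The estimate for compound 3 in this assay is 3500 nM, within a range from 1200 nM to 10000 nM.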

Compound 3, concentration for 50% growth inhibition: 14000 nM
Beside the measured number, compound 3's estimate is 4.0-fold (0.60 log units) below it, and the stated range ends below it.
By their numbers in this assay, from the lowest: compound 2; then compounds 3 and 1 (each within the scatter of the next).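

In this assay, among these compounds, tert-butyl in place of phenyl on an aromatic carbon, para to a large group, gives a 5.4-fold higher number from compound 2 to compound 3 (0.73 log units; beyond the scatter) and is the first single change sized on the shared core, showing that the number depends on which of these two groups stands at this position. The other new step, 4-(tert-butyl)phenyl in place of naphthalen-1-yl on a saturated chain carbon bound to an amine nitrogen, gives a 1.5-fold lower number from compound 1 to compound 3 (0.18 log units; within the scatter) and does not separate those two compounds, so among the three only compound 2 stands apart from the others beyond the scatter. Nothing available bears on why the phenyl and the tert-butyl differ in this way, and the data offer no explanation for the step.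

The compounds shown leave open whether the aromatic ring of the phenyl is what matters, a question that cyclohexyl at the same position would address. They also leave open how a carboxylic acid or an amine on that aromatic carbon would compare with phenyl and tert-butyl.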